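The source may report more compounds than this note shows. Statements on the series, on what has been measured and on what is new or still open speak of the compounds shown alone.

Compound 1 `CCN(CC)c1ccc(NC(=O)c2c(-c3c(Cl)cccc3Cl)noc2C)c(C(F)(F)F)c1`, compound 2 `CCN(C(C)=O)c1ccc(NC(=O)c2c(-c3c(Cl)cccc3Cl)noc2C)cc1` and compound 3 `CCN(CC)c1ccc(NC(=O)c2c(-c3ccccc3-c3ccccc3)noc2C)cc1` share a common core, differing in the groups hung on it, and all three have been measured in an assay on isolated protein for binding affinity to growth hormone secretagogue receptor type 1 (Homo sapiens); on this read-out lower numbers stand for stronger inhibition and higher numbers for weaker inhibition. In this assay compound 1 gives 4100 nM. For compound 2 this assay reports only a limit, > 10000 nM, and no number. Compound 3 gives 1300 nM, the lower of the two numbers that were obtained, while compound 1 gives the higher.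

Compound 4 `CCN(CC)c1ccc(NC(=O)c2c(-c3ccccc3)noc2C)cc1` has not yet been measured. It differs from compound 3 in a single place: hydrogen in place of phenyl on an aromatic carbon. For the measured compounds named here, no measured pair of compounds here differs by this change alone, so there is no direct guide to how large its effect will be. On the basis of the compounds that have been measured, the step from compound 3 to compound 4 is expected to weaken binding noticeably, by about a 3.8-fold higher number from compound 3 to compound 4 (0.59 log units; beyond the scatter). Compound 4 is therefore expected to give roughly 5000 nM in this assay, with a likely range from 1500 nM to 15000 nM, and some chance that this assay reports only a limit.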

Compound 4, half-maximal inhibitory concentration: 8200 nM
Compound 4: middle estimate off by 1.6-fold (0.21 log units), on the low side; the measured number falls inside the stated range.
By their numbers in this assay, from the lowest: compound 3; then compounds 1 and 4 (each within the scatter of the next). At a limit, above all of these: compound 2.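

For the compounds shown here, this pair gives the first direct reading of a single change, since no earlier pair of measured compounds differed in one place only. In this assay, replacing the phenyl with hydrogen on this aromatic carbon, ortho to a large group, gives a 6.3-fold higher number from compound 3 to compound 4 (0.80 log units; beyond the scatter), so binding clearly responds to what sits at this position, though the step is modest in size. Nothing measured here explains why the phenyl gives the lower number.

A single pair cannot show whether a whole phenyl ring is needed at this position or whether a much smaller group, such as a methyl or a methoxy, would serve as well. It also leaves open how an amine or a carboxylic acid at the same place would behave.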